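Extending a urea chain on a quinoline-like core

A few compounds are considered here, and "the series" means these few. Any claim that something is new, unique, unknown or untested is made for them only; others in the source may bear on it.

Compound 1 `COc1cc(NC(C)CCCNC(=O)Nc2cccc(F)c2)c2ncccc2c1` was tested in a functional assay on HeLa cells (Homo sapiens) for inhibition, read by MTT assay, with a stated time of 72 h (on this read-out lower numbers stand for stronger inhibition and higher numbers for weaker inhibition), and gave 18000 nM; this is the highest number of the three measured, so it is the weakest inhibitor in this set. Compound 2 `COc1cc(NC(C)CCCNC(=O)Nc2ccc(C(F)(F)F)cc2)c2ncccc2c1` gives 8300 nM, and compound 3 `COc1cc(NC(C)CCCNC(=O)NNC(=O)Nc2cccc(C(F)(F)F)c2)c2ncccc2c1` gives 4900 nM. Within the data shown here, the only single-point step recorded is a 2.2-fold lower number from compound 1 to compound 2 (0.34 log units; beyond the scatter), a change of the aromatic ring alone. Compound 4 `COc1cc(NC(C)CCCNC(=O)NNC(=O)Nc2cccc(Cl)c2)c2ncccc2c1` differs from compound 1 by ((3-chlorophenyl)carbamoyl)amino in place of 3-fluorophenyl on an amide-type nitrogen. Among the measured compounds shown here, no step pairs compound 1 with compound 3 directly, but their two values show that inserting a carbamoylamino link while moving to a trifluoromethylphenyl ring coincides with a clearly lower number. Compound 4 carries the same inserted link with a chlorophenyl ring instead, so a step of similar size and direction is expected, a 3.0-fold lower number from compound 1 to compound 4 (0.48 log units; beyond the scatter). The estimated value for compound 4 is 6000 nM, expected to lie between 2500 nM and 15000 nM.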

Compound 4, half-maximal inhibitory concentration: 44000 nM
Beside the measured number, compound 4's estimate is 7.3-fold (0.87 log units) below it; measured number outside the range, above it.
By their numbers in this assay, from the lowest: compounds 3 and 2 (each within the scatter of the next); then compound 1; then compound 4.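

In this assay, the inserted link does not bring a lower number on its own terms: with ((3-chlorophenyl)carbamoyl)amino in place of 3-fluorophenyl there is a 2.4-fold higher number from compound 1 to compound 4 (0.39 log units; beyond the scatter), and in place of 4-(trifluoromethyl)phenyl there is a 5.3-fold higher number from compound 2 to compound 4 (0.72 log units; beyond the scatter). With the link kept, chloro in place of trifluoromethyl on an aromatic carbon alone gives a 9.0-fold higher number from compound 3 to compound 4 (0.95 log units; beyond the scatter), so in this longer series that one ring substituent separates a compound with a lower number than compound 1 from one with a higher number. Nothing available explains this difference.

The effect of the link itself remains unresolved, as no pair shown keeps the same ring substituent with and without it. As far as these compounds go, whether a nitrile on that ring would behave like chloro or like trifluoromethyl also stays open.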